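The source may report more compounds than this note shows. Statements on the series, on what has been measured and on what is new or still open speak of the compounds shown alone.

The series rests on one shared core, seen in compound 1 `N#CC1=C(N)Oc2c(c3nc4ccccc4nc3c3ccccc23)C12C(=O)N(Cc1cnnn1-c1cccc(Cl)c1)c1ccccc12`, compound 2 `N#CC1=C(N)Oc2c(c3nc4ccccc4nc3c3ccccc23)C12C(=O)N(Cc1cnnn1-c1ccc(Cl)c(Cl)c1)c1ccccc12` and compound 3 `CCOc1ccc(-n2nncc2CN2C(=O)C3(C(C#N)=C(N)Oc4c(N)cc5nc6ccccc6nc5c43)c3ccccc32)cc1`, the three differing at the aryl group carried on the five-membered aromatic ring with three nitrogens. In a functional assay on HepG2 cells (Homo sapiens) for antiproliferative activity, read by MTT assay, with a stated time of 48 h (on this read-out lower numbers stand for stronger inhibition and higher numbers for weaker inhibition), compound 1 gives > 50000 nM, which is a limit of the assay and not a number. In this assay compound 2 gives > 50000 nM, again a limit. The step that the two limits leave unreadable from compound 1 to compound 2 is therefore unreadable. In this assay compound 3 stands at > 50000 nM, also a limit. The whole of the evidence on the measured steps is the limit of > 50000 nM in this assay, at which 3 of the 3 values shown sit.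

Compound 4 `N#CC1=C(N)Oc2c(N)cc3nc4ccccc4nc3c2C12C(=O)N(Cc1cnnn1-c1ccc(Cl)cc1[N+](=O)[O-])c1ccccc12` has not yet been measured. It differs from compound 3 by 4-chloro-2-nitrophenyl in place of 4-ethoxyphenyl on an aromatic nitrogen. For the measured compounds named here, no measured step bears on this change: the only step between measured compounds cannot be read, and none of the measured compounds alters the group on the aromatic nitrogen. Because all values shown sit at the limit of > 50000 nM in this assay, at which 3 of the 3 values shown sit, no step beyond the scatter can be grounded in the data. Compound 4 is expected to give 70000 nM in this assay, with a range from 20000 nM to 250000 nM, most probably as a limit once more. The step that the limit leaves unreadable from compound 3 to compound 4 is expected to stay within the scatter.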

Compound 4, half-maximal inhibitory concentration: > 50000 nM
Compound 4: only a limit was reported; the forecaster's own chance of this, stated with the estimate: 85%; the middle value lies beyond the limit too.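

In this assay compound 4 gives > 50000 nM, which is a limit of the assay and not a number. Compound 3 also stands at a limit, so no new step can be read between compound 3 and compound 4. The compounds shown leave open whether any aryl group on the aromatic nitrogen would give a measurable value, as the whole evidence is: the limit of > 50000 nM in this assay, at which 4 of the 4 values shown sit.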